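Series notes: ring change on the sulfur-linked aryl group

The source may report more compounds than this note shows. Statements on the series, on what has been measured and on what is new or still open speak of the compounds shown alone.

Measured so far in a functional assay on HCT-116 cells (Homo sapiens) for inhibition, read by luminescence, with a stated time of 72 h; a lower number here means a stronger inhibitor, a higher number a weaker inhibitor:
Compound 1 `Nc1ncnc2c1nc(Sc1cc3c(cc1Br)CCO3)n2CCC1CCN(C=O)CC1` gives 90 nM.
Compound 2 `C[C@H](O)C(=O)N1CCC(CCn2c(Sc3cc4c(cc3Br)CCO4)nc3c(N)ncnc32)CC1` gives 210 nM.

Compound 2 holds the higher of the two numbers, with compound 1 the nearer one. Among the compounds with values here, the single step recorded, a 2.3-fold higher number from compound 1 to compound 2 (0.37 log units; beyond the scatter), concerns the carbonyl carbon and not the sulfur-linked aryl group.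

Compound 3 `C[C@H](O)C(=O)N1CCC(CCn2c(Sc3cc4c(cc3Br)OCCO4)nc3c(N)ncnc32)CC1` differs from compound 2 by a group of 11 heavy atoms (8 carbon, 2 oxygen, 1 bromine; one six-membered non-aromatic ring with 2 hetero atoms, one six-membered aromatic ring of carbon only) in place of a group of 10 heavy atoms (8 carbon, 1 oxygen, 1 bromine; one five-membered non-aromatic ring with 1 hetero atom, one six-membered aromatic ring of carbon only), on a sulfur. Within the data shown here, no measured step touches this part of the structure, so the data give no direction for it. The step from compound 2 is therefore expected to be small, a 1.2-fold higher number from compound 2 to compound 3 (0.08 log units; within the scatter), with a wide range. Compound 3 is estimated at 250 nM, between 90 nM and 700 nM.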

Compound 3, half-maximal inhibitory concentration: 470 nM
For compound 3 the middle estimate is 1.9-fold (0.27 log units) below the measured one; measured number inside the range.
By their numbers in this assay, from the lowest: compound 1; then compound 2; then compound 3.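

The sulfur-linked aryl group is not a neutral position in this assay: putting 7-bromo-2,3-dihydro-1,4-benzodioxin-6-yl on the sulfur gives a 2.2-fold higher number from compound 2 to compound 3 (0.35 log units; beyond the scatter). Of the two ring sizes shown, the five-membered non-aromatic ring with 1 hetero atom gives the lower number. No measurement at hand bears on the reason for this step.

Open, on these data alone, is how chlorine or a methoxy group in place of the bromine would read at this position. Also open, as far as these compounds go, is whether the same ring change gives a similar step when the 1-hydroxyethyl group is replaced by the hydrogen of compound 1.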